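Removing the amino group from compound 1: working notes

The compounds below may be only part of what the source reports. "The series", "measured", "known", "first", "only" and "open" are said of these compounds alone.

Of the compounds shown here, two have been measured so far. Compound 1 `Nc1nc(Cl)c2ncn(Cc3ccccc3CCl)c2n1` carries a benzyl group bearing a chloromethyl group, with an amino group and a chloro group on the shared core. In a functional assay on SNB-19 cells (Homo sapiens) for cytotoxicity, read by sulforhodamine B assay, with a stated time of 48 h (a higher number here means a weaker inhibitor of growth, a lower number a stronger inhibitor of growth), compound 1 gives 6030 nM. Compound 2 `Nc1nc(Cl)c2ncn(Cc3cccc(CCl)c3)c2n1` differs only in where the chloromethyl group sits on the benzyl ring, and in this assay compound 2 gives 3160 nM. Compound 1 has the higher of the two numbers, but the gap to compound 2 lies within the scatter, so the two are not separated by these data. Among the measured compounds shown here, no step between measured compounds that differ in a single place exists, so no change on the core has yet been tested.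

Compound 3 `ClCc1ccccc1Cn1cnc2c(Cl)ncnc21` is the next compound to be run. Against compound 1 the change is hydrogen in place of amino on an aromatic carbon. For the measured compounds named here, with no measured precedent, the expectation rests on the structural change alone. A step of a 1.5-fold higher number from compound 1 to compound 3 (0.17 log units; within the scatter) is expected, toward a higher number, modest and possibly not beyond the scatter. For compound 3 the estimate is 9000 nM, with a range from 3000 nM to 27000 nM.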

Compound 3, concentration for 50% growth inhibition: 5370 nM
Estimate against measurement, compound 3: 1.7-fold (0.22 log units) above; the measured number falls inside the stated range.
By their numbers in this assay, from the lowest: compounds 2, 3 and 1 (each within the scatter of the next).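

In this assay, among the compounds shown here, hydrogen in place of amino gives a 1.1-fold lower number from compound 1 to compound 3 (0.05 log units; within the scatter), and this is the first step that reads a change on the shared core rather than a comparison of where the chloromethyl group sits on the benzyl ring. On this aromatic carbon, between two ring nitrogen atoms, the amino group and hydrogen are not separated by this assay, so growth inhibition on these cells does not depend measurably on the amino group in the setting of compound 1. No measurement at hand speaks to why the two compounds are not separated.

The compounds shown leave open whether this result holds with the chloromethyl group placed as in compound 2, and whether a methoxy or dimethylamino group on the same carbon would move the number beyond the scatter. They also leave open how much the growth inhibition rests on the chloromethyl group itself, which a plain methyl group in its place would test, and on the chloro group of the core, which an amine in its place would test.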